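Alpha-branching of the acid head group in this series

A few compounds are considered here, and "the series" means these few. Any claim that something is new, unique, unknown or untested is made for them only; others in the source may bear on it.

Measured compounds:
compound 1, `COc1ccc(F)c([C@H]2CC[C@H](COc3cccc([C@@H](CC(=O)O)C4CC4)c3)CC2)c1`, a functional assay on HEK293 cells for agonist activity at Free fatty acid receptor 1 (Homo sapiens), read by FLIPR and calcium flux (on this read-out higher numbers stand for an effect only at larger amounts of compound and lower numbers for an effect already at smaller amounts), 0.94 nM
compound 2, `COc1ccc(F)c([C@H]2CC[C@H](COc3cccc([C@H](C4CC4)[C@](C)(F)C(=O)O)c3)CC2)c1`, this assay 6.1 nM

Compound 2 stands at the highest number of the two; compound 1 is the nearest, at a lower number beyond the scatter. Compound 3 `COc1ccc(F)c([C@H]2CC[C@H](COc3cccc([C@H](C4CC4)C(C)(C)C(=O)O)c3)CC2)c1` carries the change (1-carboxy-1-methylethyl in place of 1-carboxy-1-fluoroethyl on a saturated chain carbon bound to an aromatic carbon and a saturated ring carbon). For the measured compounds named here, the only measured step that bears on it is a 6.5-fold higher number from compound 1 to compound 2 (0.81 log units; beyond the scatter), where 1-carboxy-1-fluoroethyl replaced carboxymethyl and raised the number. Swapping fluorine for methyl on that branched group has no measured precedent, so a small rise or no change is expected, an estimated step of a 1.6-fold higher number from compound 2 to compound 3 (0.21 log units; within the scatter). Compound 3 is estimated at 10 nM, range 3 nM to 35 nM.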

Compound 3, half-maximal effective concentration: 0.11 nM
Beside the measured number, compound 3's estimate is 91-fold (1.96 log units) above it, outside the stated range (below it).
By their numbers in this assay, from the lowest: compound 3; then compound 1; then compound 2.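

On a saturated chain carbon bound to an aromatic carbon and a saturated ring carbon, a branched acid group is not in itself a loss in this assay since 1-carboxy-1-methylethyl in place of carboxymethyl gives an 8.5-fold lower number from compound 1 to compound 3 (0.93 log units; beyond the scatter) in the opposite direction to the fluorinated group. The exchange within the branched group carries the larger change at a 55-fold lower number from compound 2 to compound 3 (1.74 log units; beyond the scatter) and also removes a defined stereocentre. Nothing at hand accounts for this difference. Still open, on these data alone, is how 1-carboxycyclopropyl or the longer 1-carboxy-1-methylpropyl would read at this place. As far as these compounds go, the opposite configuration of the fluorinated group in compound 2 also remains open.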